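A New Amino Group on the Sulfonyl Sulfur

This account rests on a few compounds, and the source may have more. Where it says the series, first, only, none or still open, it means among the compounds named here.

Compound 1 (`Cc1cccc(N(C)S(=O)(=O)C2CC3OC2C(c2ccc(NC(=O)CCCCCCC(=O)O)cc2)=C3c2ccc(O)cc2)c1`) gives 30200 nM in a functional assay on MCF7 cells (Homo sapiens) for antiproliferative activity, read by MTT assay, with a stated time of 72 h (a lower number here means a stronger inhibitor, a higher number a weaker inhibitor), and stands within the scatter of both compounds measured alongside it. Compound 2 (`CCN(c1ccccc1)S(=O)(=O)C1CC2OC1C(c1ccc(NC(=O)CCCCCCC(=O)O)cc1)=C2c1ccc(O)cc1`) reads 19100 nM and compound 3 (`CCN(c1ccc(C)cc1)S(=O)(=O)C1CC2OC1C(c1ccc(NC(=O)CCCCCCC(=O)O)cc1)=C2c1ccc(O)cc1`) reads 42300 nM on the same scale. The two steps away from compound 1 are small, namely a 1.6-fold lower number from compound 1 to compound 2 (0.20 log units; within the scatter) and a 1.4-fold higher number from compound 1 to compound 3 (0.15 log units; within the scatter) as measured. Only a 2.2-fold higher number from compound 2 to compound 3 (0.35 log units; beyond the scatter) passes the scatter, a modest step for methyl in place of hydrogen on an aromatic carbon.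

Compound 4 (`CCN(c1ccc(OC)cc1)S(=O)(=O)C1CC2OC1C(c1ccc(NC(=O)CCCCCCC(=O)O)cc1)=C2c1ccc(O)cc1`) has ethyl(4-methoxyphenyl)amino in place of methyl(3-methylphenyl)amino on a sulfonyl sulfur, and ethyl(4-methoxyphenyl)amino in place of methyl(3-methylphenyl)amino on a sulfonyl sulfur gives the count of that change. The closest measured change is the one to ethyl(4-methylphenyl)amino, where a 1.4-fold higher number from compound 1 to compound 3 (0.15 log units; within the scatter) stayed within the scatter, so no step beyond the scatter is expected in this assay here. The expected step is a 1.1-fold higher number from compound 1 to compound 4 (0.03 log units; within the scatter) on this estimate. The estimate for compound 4 is 32000 nM as its expected value, with 15000 nM to 65000 nM as its range.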

Compound 4, half-maximal inhibitory concentration: 20300 nM
Compound 4: the middle estimate sits 1.6-fold (0.20 log units) above what was measured; low and high end bracket the measured number.
By their numbers in this assay, from the lowest: compounds 2, 4, 1 and 3 (each within the scatter of the next, the first and the last beyond it).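

In this assay, the aromatic carbon of the ethyl-bearing arylamino group now separates two substituents: methoxy in place of methyl gives a step beyond the scatter (a 2.1-fold lower number from compound 3 to compound 4 (0.32 log units; beyond the scatter)), while methoxy in place of hydrogen stays within it (a 1.1-fold higher number from compound 2 to compound 4 (0.03 log units; within the scatter)). The modest penalty seen with methyl at this carbon is therefore not shared by methoxy, and the exchange on the sulfonyl sulfur stays small (a 1.5-fold lower number from compound 1 to compound 4 (0.17 log units; within the scatter)) even though the entering group carries a hydrogen-bond acceptor that the leaving group lacks. No measurement here accounts for the difference between methyl and methoxy.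

The compounds shown leave open whether chloro or hydroxy on that aromatic carbon would behave like methyl or like methoxy. They also leave open how a propyl group on the sulfonamide nitrogen would read.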